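The source may report more compounds than this note shows. Statements on the series, on what has been measured and on what is new or still open speak of the compounds shown alone.

Three compounds share one core and differ from each other in a single place. In an ADME assay on L02 cells (Homo sapiens) for cytotoxicity, read by MTT assay, with a stated time of 24 h (on this read-out lower numbers stand for stronger inhibition and higher numbers for weaker inhibition), compound 1 `O=C1/C(=C/c2ccccc2F)CN(S(=O)(=O)c2ccc(F)cc2)C/C1=C\c1ccccc1F` gives 17500 nM, compound 2 `O=C1/C(=C/c2cccc(F)c2)CN(S(=O)(=O)c2ccccc2)C/C1=C\c1cccc(F)c1` gives 16200 nM, and compound 3 `Cc1ccc(S(=O)(=O)N2C/C(=C\c3cccc(F)c3)C(=O)/C(=C/c3cccc(F)c3)C2)cc1` gives 15700 nM; these three numbers lie within the scatter of one another, so compound 3 cannot be set apart from the other two. Going by the values given here, the only single-point step among them, a 1.0-fold lower number from compound 2 to compound 3 (0.01 log units; within the scatter), stayed within the scatter. Compound 4 `O=C1/C(=C/c2cccc(F)c2)CN(S(=O)(=O)c2ccc(O[N+](=O)[O-])cc2)C/C1=C\c1cccc(F)c1` carries the change (nitrooxy in place of methyl on an aromatic carbon). Among the compounds with values here, no measured step involves nitrooxy, and the one measured step at this place was flat, so no shift beyond the scatter is expected in this assay a 1.0-fold higher number from compound 3 to compound 4 (0.01 log units; within the scatter). Compound 4 is therefore estimated at 16000 nM, with a range from 8000 nM to 32000 nM.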

Compound 4, half-maximal inhibitory concentration: 10700 nM
Compound 4: the middle estimate sits 1.5-fold (0.17 log units) above what was measured; low and high end bracket the measured number.
By their numbers in this assay, from the lowest: compounds 4, 3, 2 and 1 (each within the scatter of the next).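

In this assay, nitrooxy on this aromatic carbon gives a 1.5-fold lower number from compound 3 to compound 4 (0.17 log units; within the scatter) where it replaces methyl, and a 1.5-fold lower number from compound 2 to compound 4 (0.18 log units; within the scatter) where it replaces hydrogen. This position, flat for methyl, thus also takes a group with more heavy atoms and with hydrogen-bond acceptors without a shift beyond the scatter. No measurement offered here bears on the cause of these numbers. The compounds shown leave open whether an amine, a carboxylic acid or a longer chain at this place would also stay within the scatter.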